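Swapping a nitrile for a methyl on the benzyl arm

This account rests on a few compounds, and the source may have more. Where it says the series, first, only, none or still open, it means among the compounds named here.

Compound 1, `CCOC(=O)Cn1cc(CNC(=O)c2cnc(Nc3ccc(C#N)cc3)cc2Oc2c(C)cc(C)cc2C)nn1`, gives 9530 nM in an ADME assay on MT4 cells (Homo sapiens) for cytotoxicity, read by MTT assay, with a stated time of 5 days; on this read-out higher numbers stand for lower toxicity in this test and lower numbers for higher toxicity in this test.
Compound 2, `Cc1cc(C)c(Oc2cc(Nc3ccc(C#N)cc3)ncc2C(=O)NCc2cn(Cc3ccccc3C#N)nn2)c(C)c1`, gives > 219000 nM, which is a limit of the assay.
Compound 3, `Cc1cc(C)c(Oc2cc(Nc3ccc(C#N)cc3)ncc2C(=O)NCc2cn(Cc3ccc([N+](=O)[O-])cc3)nn2)c(C)c1`, gives >= 139000 nM, which is also a limit of the assay.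

The three measured compounds share one core and differ only in the group on the saturated chain carbon bound to an aromatic nitrogen. Compound 2 sits at a limit, so its number is not a measured value but the edge of what the assay could resolve; see (the limit of > 219000 nM in this assay, at which 1 of the 3 values shown sits). Compound 3 likewise sits at a limit, (the limit of >= 139000 nM in this assay, at which 1 of the 3 values shown sits).

Compound 4, `Cc1cc(C)c(Oc2cc(Nc3ccc(C#N)cc3)ncc2C(=O)NCc2cn(Cc3ccccc3C)nn2)c(C)c1`, has not been measured. It differs from compound 2 by methyl in place of cyano on an aromatic carbon.

Two measured steps speak to the aryl-bearing compounds in general: an at least 22-fold higher number from compound 1 to compound 2 (1.36 log units; beyond the scatter) and an at least 14-fold higher number from compound 1 to compound 3 (1.16 log units; beyond the scatter). Between the two aryl compounds themselves, a step that the two limits leave unreadable from compound 2 to compound 3, because both sit at limits. For the measured compounds named here, no measured step addresses a methyl for a cyano on that ring, so the direction of the present change cannot be read from the data; both aryl analogues reaching limits suggests compound 4 is expected to stay high as well, most likely again at a limit.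

Compound 4 is therefore expected to give 200000 nM, within 50000 nM to 400000 nM, which corresponds to an expected at least 1.0-fold lower number from compound 2 to compound 4 (0.03 log units; that floor lies within the scatter).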

Compound 4, half-maximal cytotoxic concentration: >= 164000 nM
Compound 4 gave a limit, no number (the forecaster's own chance of this, stated with the estimate: 70%); the middle value lies beyond the limit too.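

Compound 4 adds a third case in which an aryl group on the saturated chain carbon takes the read-out to a limit of the assay, and here the ring carries a methyl rather than a nitrile or nitro group. In this assay, 2-methylphenyl in place of ethoxycarbonyl gives an at least 17-fold higher number from compound 1 to compound 4 (1.23 log units; beyond the scatter), so a higher number no longer depends on a nitrile or nitro group on that ring; among the four compounds, compound 1 with its ethoxycarbonyl is the only one that does not sit at a limit. The steps among compound 2, compound 3 and compound 4 cannot be read, so methyl in place of cyano has no measurable size here and these three compounds cannot be ranked.

As far as these compounds go, it stays open how far past their limits these three compounds lie, and whether any group on that ring would lower the number at all. From the compounds shown here alone, it also stays open what a carboxylic acid or a simple amine on the same chain carbon would give, which would show whether the lower number of compound 1 belongs to the ethoxycarbonyl group alone.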